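The source may hold more compounds than are shown below. What is called first, only, known or untested is meant among the compounds shown, and "the series" means these compounds.

Of the compounds shown here, three built on one shared core have been tested in a functional assay on HeLa cells (Homo sapiens) for inhibition, read by MTT assay, with a stated time of 72 h; on this read-out higher numbers stand for weaker inhibition and lower numbers for stronger inhibition. Compound 1 `Cc1noc(C)c1-c1cnc(N)c(Oc2ccc(C(=O)NC3CCCC3)cc2)n1` gives 9970 nM in this assay. Compound 2 `Cc1noc(C)c1-c1cnc(N)c(Oc2ccc(C(=O)Nc3ccccc3Cl)cc2)n1` gives 81300 nM, and compound 3 `Cc1noc(C)c1-c1cnc(N)c(Oc2ccc(C(=O)Nc3ncccc3Cl)cc2)n1` gives 31900 nM. Among these three numbers compound 2 stands highest, which here means the weakest inhibition: the change from compound 1 to compound 2 brought an 8.2-fold higher number from compound 1 to compound 2 (0.91 log units; beyond the scatter), and the step from compound 2 to compound 3 was a 2.5-fold lower number from compound 2 to compound 3 (0.41 log units; beyond the scatter).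

Compound 4 `Cn1cc(-c2cnc(N)c(Oc3ccc(C(=O)Nc4ccccc4Cl)cc3)n2)cn1` is the next compound, and it differs from compound 2 in a single spot: 1-methyl-1H-pyrazol-4-yl in place of 3,5-dimethyl-1,2-oxazol-4-yl on an aromatic carbon. The three measured steps all concern the group on the amide nitrogen, namely an 8.2-fold higher number from compound 1 to compound 2 (0.91 log units; beyond the scatter), a 3.2-fold higher number from compound 1 to compound 3 (0.51 log units; beyond the scatter) and a 2.5-fold lower number from compound 2 to compound 3 (0.41 log units; beyond the scatter), and in every one of them the five-membered ring stayed the same. Among the measured compounds shown here, no measured step therefore bears directly on this change, and there is nothing in these data that points to a shift in either direction. The expectation for compound 4 is accordingly a step of a 1.3-fold lower number from compound 2 to compound 4 (0.10 log units; within the scatter) in this assay, that is no change beyond the scatter, with a wide range to reflect the lack of any guide. Compound 4 is estimated at 65000 nM, between 15000 nM and 280000 nM.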

Compound 4, half-maximal inhibitory concentration: 73000 nM
Compound 4: the middle estimate sits 1.1-fold (0.05 log units) below what was measured, and the stated range covers the measured number.
By their numbers in this assay, from the lowest: compound 1; then compound 3; then compounds 4 and 2 (each within the scatter of the next).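

In this assay, among the compounds shown here, the change on the aromatic carbon gives a 1.1-fold lower number from compound 2 to compound 4 (0.05 log units; within the scatter) and so stays within the scatter, whereas the earlier steps at the amide nitrogen, such as an 8.2-fold higher number from compound 1 to compound 2 (0.91 log units; beyond the scatter), lay beyond it. For the compounds shown here, this is the first measured look at the five-membered ring, and with the 2-chlorophenyl amide in place, 1-methyl-1H-pyrazol-4-yl and 3,5-dimethyl-1,2-oxazol-4-yl cannot be told apart on this read-out, even though one ring holds an oxygen and the other a second nitrogen. No supporting measurement is available to explain why the two rings read alike at this position.

Going by these compounds, whether this swap would also leave the number unchanged with a different amide group remains open, for instance on compound 1 , which gives 9970 nM and has a cyclopentyl group on the amide nitrogen. On these data alone, it is also open what quite different groups would do on this aromatic carbon, such as a plain phenyl ring, an amine like morpholine or a carboxylic acid.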